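Replacing Trifluoromethoxy with Methoxycarbonyl on the Shared Core

The source may report more compounds than this note shows. Statements on the series, on what has been measured and on what is new or still open speak of the compounds shown alone.

Three compounds share one core and differ only in the group on one aromatic carbon. Compound 3 `Cc1c(C(=O)Nc2ccc(Oc3ncnc4[nH]cc(-c5ccccc5)c34)c(F)c2)c(=O)c2cc(OC(F)(F)F)ccc2n1C` gives 74 nM in an assay on isolated protein for inhibition of tyrosine-protein kinase receptor UFO (Homo sapiens), read by FRET and Z'-LYTE, with a stated time of 1.5 h; on this read-out higher numbers stand for weaker inhibition and lower numbers for stronger inhibition. Compound 1 `Cc1c(C(=O)Nc2ccc(Oc3ncnc4[nH]cc(-c5ccccc5)c34)c(F)c2)c(=O)c2cc(C(C)(C)C)ccc2n1C` gives 42 nM, and compound 2 `Cc1c(C(=O)Nc2ccc(Oc3ncnc4[nH]cc(-c5ccccc5)c34)c(F)c2)c(=O)c2cc(C3CCCC3)ccc2n1C` gives 200 nM. Compound 3 thus holds the second highest of the three numbers: the step of a 1.8-fold higher number from compound 1 to compound 3 (0.25 log units; within the scatter) lies within the scatter, whereas a 2.7-fold lower number from compound 2 to compound 3 (0.43 log units; beyond the scatter) lies beyond it. Compound 4 `COC(=O)c1ccc2c(c1)c(=O)c(C(=O)Nc1ccc(Oc3ncnc4[nH]cc(-c5ccccc5)c34)c(F)c1)c(C)n2C` carries methoxycarbonyl in place of trifluoromethoxy on an aromatic carbon. Among the measured compounds shown here, the steps of a 1.8-fold higher number from compound 1 to compound 3 (0.25 log units; within the scatter) and a 2.7-fold lower number from compound 2 to compound 3 (0.43 log units; beyond the scatter) show that exchanging the group at this position shifts the number only modestly, but no measured compound carries methoxycarbonyl there, so the direction remains open. Compound 4 is therefore expected to give about 100 nM, between 30 nM and 400 nM. The step of a 1.4-fold higher number from compound 3 to compound 4 (0.13 log units; within the scatter) is expected to stay within the scatter.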

Compound 4, half-maximal inhibitory concentration: > 10000 nM
Compound 4: no number, only a limit; the forecaster's own chance of this, stated with the estimate: 5%; at least 100-fold (2.00 log units) between middle value and limit.
By their numbers in this assay, from the lowest: compounds 1 and 3 (each within the scatter of the next); then compound 2. At a limit, above all of these: compound 4.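

For compound 4 the read-out gives only a limit, not a number: the limit of > 10000 nM in this assay, at which 1 of the 4 values shown sits. So far, tert-butyl, cyclopentyl and trifluoromethoxy had all given measurable numbers at this position, but methoxycarbonyl gives an at least 130-fold higher number from compound 3 to compound 4 (2.13 log units; beyond the scatter), an at least 50-fold higher number from compound 2 to compound 4 (1.69 log units; beyond the scatter) and an at least 230-fold higher number from compound 1 to compound 4 (2.37 log units; beyond the scatter). The position is therefore far less forgiving than the three earlier compounds suggested, and a single exchange here can remove nearly all measurable inhibition.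

On these data alone, it remains open whether this loss belongs to methoxycarbonyl as a whole or to one part of it. A carboxylic acid, an acetyl group or a primary amide at this position would help to separate these possibilities.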